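The source may report more compounds than this note shows. Statements on the series, on what has been measured and on what is new or still open speak of the compounds shown alone.

Measured compounds:
- compound 1, `Cc1c(C)n(C(=O)c2ccc(O)c(C#N)c2)c2ccccc12`: in an assay on tissue (RPTEC cells) for inhibition of solute carrier family 22 member 12 (Homo sapiens), read by scintillation counting, with stated times of 15 min and 2 h (a higher number here means a weaker inhibitor, a lower number a stronger inhibitor), compound 1 gives 10800 nM
- compound 2, `N#Cc1cc(C(=O)N2CCc3ccccc32)cc(I)c1O`: in this assay compound 2 gives 5300 nM

Compound 2 holds the lower of the two numbers in this assay; compound 1 sits higher by a margin that is beyond the usual scatter. Only these two points exist, and they differ in more than one place, so no single change can be isolated from them.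

Compound 3, `CC(C)(C)c1cc(C(=O)N2CCc3ccccc32)cc(C#N)c1O`, keeps the core of compound 2 and differs in one place: tert-butyl in place of iodo on an aromatic carbon. The iodo group and the tert-butyl group are of similar bulk, and nothing in the two measured compounds separates the contribution of the substituent on that aromatic carbon from the rest of the molecule. No directional step is expected beyond the scatter for this exchange. The step expected is a 1.3-fold lower number from compound 2 to compound 3 (0.12 log units; within the scatter), which lies within the scatter. Compound 3 is estimated at 4000 nM in this assay, with a range from 1500 nM to 12000 nM.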

Compound 3, half-maximal inhibitory concentration: 31600 nM
For compound 3 the middle estimate is 7.9-fold (0.90 log units) below the measured one; the measured number lies above the stated range.
By their numbers in this assay, from the lowest: compound 2; then compound 1; then compound 3.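

In this assay, tert-butyl in place of iodo on this aromatic carbon, ortho to a hydroxy group and meta to a cyano group, gives a 6.0-fold higher number from compound 2 to compound 3 (0.78 log units; beyond the scatter), so the inhibition read here depends on which of these two groups the position carries. The exchange leaves the counts of hydrogen-bond donors, hydrogen-bond acceptors and net charge unchanged, and replaces 1 iodine with 4 carbon atoms, so compound 3 is the weaker inhibitor without any change in those polar counts. No measurement at hand bears on the origin of this step.

With only iodo and tert-butyl at this position, the compounds shown cannot tell whether the step follows the departure of iodo or the arrival of tert-butyl, and bromo, methyl or a carboxylic acid on the same carbon would help to separate the two. Going by these compounds, it also remains open whether the same exchange would give a step of similar size on the core of compound 1, which carries neither group.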